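Swapping an Acetylphenoxy Ester for a Quinolinyloxy Ester

The source may report more compounds than this note shows. Statements on the series, on what has been measured and on what is new or still open speak of the compounds shown alone.

Three esters built on one shared core have been measured. In a functional assay on SGC-7901 cells (Homo sapiens) for cytotoxicity, read by sulforhodamine B assay, with a stated time of 72 h (on this read-out lower numbers stand for stronger inhibition and higher numbers for weaker inhibition), compound 1 `C=C1C(=O)O[C@@H]2CC(C)=C([C@@H](C)CCCOC(C)=O)[C@@H](OC(=O)CCl)[C@H]12` gives 26500 nM, compound 2 `C=C1C(=O)O[C@@H]2CC(C)=C([C@@H](C)CCCOC(C)=O)[C@@H](OC(=O)CN3CCCCC3)[C@H]12` gives 11500 nM, and compound 3 `C=C1C(=O)O[C@@H]2CC(C)=C([C@@H](C)CCCOC(C)=O)[C@@H](OC(=O)COc3cccc(C(C)=O)c3)[C@H]12` gives 46100 nM. Compound 3 carries the highest of the three numbers, though not by a wide margin: the step of a 1.7-fold higher number from compound 1 to compound 3 (0.24 log units; within the scatter) lies within the scatter, while the step of a 4.0-fold higher number from compound 2 to compound 3 (0.60 log units; beyond the scatter) lies beyond it.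

Compound 4 `C=C1C(=O)O[C@@H]2CC(C)=C([C@@H](C)CCCOC(C)=O)[C@@H](OC(=O)COc3cccc4cccnc34)[C@H]12` differs from compound 3 in one place: quinolin-8-yl in place of 3-acetylphenyl on an oxygen on a saturated carbon. Going by the values given here, no measured step touches this oxygen directly; each of them instead exchanges the whole group on the saturated chain carbon bound to the carbonyl carbon, and even the largest of those, a 4.0-fold higher number from compound 2 to compound 3 (0.60 log units; beyond the scatter), is only modest. The nearest guide is therefore that wholesale changes at this end of the molecule have moved this assay only modestly in either direction. A change that keeps the ether oxygen and trades one aromatic system for another is expected to move the number less than that, most likely not beyond the scatter.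

Compound 4 is therefore expected to give about 35000 nM in this assay, with a likely range from 12000 nM to 100000 nM, corresponding to an expected step of a 1.3-fold lower number from compound 3 to compound 4 (0.12 log units; within the scatter).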

Compound 4, half-maximal inhibitory concentration: 14300 nM
Beside the measured number, compound 4's estimate is 2.4-fold (0.39 log units) above it; the range from low to high includes it.
By their numbers in this assay, from the lowest: compounds 2, 4, 1 and 3 (each within the scatter of the next, the first and the last beyond it).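

In this assay, the ether oxygen stays and only the aromatic group on it changes, yet this one exchange gives a 3.2-fold lower number from compound 3 to compound 4 (0.51 log units; beyond the scatter). So at this position the oxygen alone does not set the number, and the group it carries matters, even though both groups count the same hydrogen-bond donors and acceptors. Compound 4 also sits with the other esters rather than apart from them, since a 1.2-fold higher number from compound 2 to compound 4 (0.09 log units; within the scatter) and a 1.9-fold lower number from compound 1 to compound 4 (0.27 log units; within the scatter) leave it unresolved from both the piperidin-1-yl ester and the chloro ester, a closeness that the 3-acetylphenoxy ester has with the chloro ester but not with the piperidin-1-yl ester. Nothing measured here speaks to why the aromatic exchange moves the number.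

The exchange removes an acetyl group while adding a second ring and a ring nitrogen, and the compounds shown do not separate these three changes. An unsubstituted phenyl group or a naphthyl group on the same oxygen would help to show which of them goes with the lower number.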